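The compounds below may be only part of what the source reports. "The series", "measured", "known", "first", "only" and "open" are said of these compounds alone.

Compound 1 `COc1ccc(-c2ssc(=S)c2-c2cc(OC)c(OC)c(OC)c2)cc1[N+](=O)[O-]` and compound 2 `COc1ccc(-c2ssc(=S)c2-c2cc(OC)c(OC)c(OC)c2)cc1N` share one core, while compound 3 `COc1ccc(-c2c(-c3cc(OC)c(OC)c(OC)c3)ss/c2=N/O)cc1[N+](=O)[O-]` and compound 4 `COc1ccc(-c2c(-c3cc(OC)c(OC)c(OC)c3)ss/c2=N/O)cc1N` share another; how the two cores differ is not broken down here. In a functional assay on KB cells (Homo sapiens) for antiproliferative activity, read by MTT assay, with a stated time of 72 h (on this read-out higher numbers stand for weaker inhibition and lower numbers for stronger inhibition), compound 1 reaches only the limit of > 100000 nM, which is a bound of the assay and not a number (the limit of > 100000 nM in this assay, at which 1 of the 3 values shown sits). Compound 2 gives 327 nM in this assay, and compound 3 gives 5260 nM. The change from compound 1 to compound 2 is amino in place of nitro on an aromatic carbon, and it made a large step of an at least 300-fold lower number from compound 1 to compound 2 (2.48 log units; beyond the scatter). The same change, (amino in place of nitro on an aromatic carbon), leads from compound 3 to compound 4, which has not been measured in this assay. Since the earlier step rests on a limit for compound 1, its full size is open; still, an improvement of similar direction is expected for compound 4, so its estimated step is a 44-fold lower number from compound 3 to compound 4 (1.64 log units; beyond the scatter). Compound 4 is therefore expected to give about 120 nM in this assay, most likely between 25 nM and 700 nM.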

Compound 4, half-maximal inhibitory concentration: 2910 nM
Estimate against measurement, compound 4: 24-fold (1.38 log units) below; the measured number lies above the stated range.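

In this assay, the change of nitro to amino does not carry over from one core to the other: on the core of compound 3 it gives only a 1.8-fold lower number from compound 3 to compound 4 (0.26 log units; within the scatter), and the two steps differ: the same change on two cores in this assay, an at least 300-fold lower number (2.48 log units; beyond the scatter) from compound 1 to compound 2 and a 1.8-fold lower number (0.26 log units; within the scatter) from compound 3 to compound 4, at least 160-fold (2.22 log units) apart, beyond the scatter of two such steps. As far as these compounds go, compound 1 stands at a limit of the assay and not at a number, so the full size of its step stays open: the limit of > 100000 nM in this assay, at which 1 of the 4 values shown sits. With one pair on each core, this shows that the size of the step depends on the core in these four compounds, but it does not show which feature of the cores is responsible, or how the change would behave on any further core.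

The compounds shown leave open whether other groups in the same place, such as a hydroxyl, a methylamino or an acetamide group, would also separate the two cores. They also leave open whether the same difference between the cores would appear in cells other than those of this assay.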